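Hydroxy for Methyl on the Aryl Piperazine Arm

The source may hold more compounds than are shown below. What is called first, only, known or untested is meant among the compounds shown, and "the series" means these compounds.

Of the compounds shown here, three sharing one core have been tested in a functional assay on SH-SY5Y cells (Homo sapiens) for inhibition, read by sulforhodamine B assay; a lower number here means a stronger inhibitor, a higher number a weaker inhibitor. Compound 1, `COC(=O)CC/C(C)=C/Cc1c(OC)c(C)c2c(c1OCC#CCN1CCN(c3ccc(C)cc3)CC1)C(=O)OC2`, gives 37700 nM in this assay. Compound 2, `COC(=O)CC/C(C)=C/Cc1c(OC)c(C)c2c(c1OCC#CCN1CCN(C(c3ccccc3)c3ccccc3)CC1)C(=O)OC2`, gives 23700 nM, and compound 3, `COC(=O)CC/C(C)=C/Cc1c(OC)c(C)c2c(c1OCC#CCN1CCC(C(=O)OC)CC1)C(=O)OC2`, gives 41200 nM. Among these three numbers compound 1 stands in the middle, and its value lies within the usual scatter of both the value of compound 2 and the value of compound 3, so no order can be read from them; all three are weak inhibitors.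

Compound 4, `COC(=O)CC/C(C)=C/Cc1c(OC)c(C)c2c(c1OCC#CCN1CCN(c3ccc(O)cc3)CC1)C(=O)OC2`, is not yet measured. It differs from compound 1 in one place: hydroxy in place of methyl on an aromatic carbon. For the measured compounds named here, the measured set offers no pair of compounds differing by such a change, so there is nothing to show how this assay responds to it. The expectation is that the step of a 1.1-fold lower number from compound 1 to compound 4 (0.03 log units; within the scatter) stays within the scatter, with no clear direction. Compound 4 is therefore estimated at 35000 nM, in a range from 14000 nM to 90000 nM.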

Compound 4, half-maximal inhibitory concentration: 46100 nM
Compound 4: middle estimate off by 1.3-fold (0.12 log units), on the low side; the range from low to high includes it.
By their numbers in this assay, from the lowest: compounds 2, 1, 3 and 4 (each within the scatter of the next).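

In this assay, for the compounds shown here, this is the first direct test of the position, and the swap from 4-methylphenyl to 4-hydroxyphenyl gives a 1.2-fold higher number from compound 1 to compound 4 (0.09 log units; within the scatter). The incoming hydroxy brings one hydrogen-bond donor and one hydrogen-bond acceptor that methyl lacks, yet this assay shows no difference that can be told from the scatter, and both compounds remain weak inhibitors. No measurement offered here gives a reason for this result.

The compounds shown leave open whether any other group in this place, para to a large group, would give a step beyond the scatter, for example an amine, a carboxylic acid or a longer chain such as ethoxy. They also leave open whether hydroxy for methyl would give a similar step on another aromatic ring of this series.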